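Bromo-to-nitro swap carried onto the piperidine analogue

The source may hold more compounds than are shown below. What is called first, only, known or untested is meant among the compounds shown, and "the series" means these compounds.

Measured so far in a functional assay on NCI-H460 cells (Homo sapiens) for cytotoxicity, read by MTT assay, with a stated time of 72 h; a lower number here means a stronger inhibitor, a higher number a weaker inhibitor:
compound 1 `COc1cc2c(Oc3ccc(NC(=O)c4nn(-c5ccc(Br)cc5)c(=O)c5ccccc45)cc3F)ccnc2cc1OCCCN1CCN(C)CC1` gives 250 nM
compound 2 `COc1cc2c(Oc3ccc(NC(=O)c4nn(-c5ccc([N+](=O)[O-])cc5)c(=O)c5ccccc45)cc3F)ccnc2cc1OCCCN1CCN(C)CC1` gives 980 nM
compound 3 `COc1cc2c(Oc3ccc(NC(=O)c4nn(-c5ccc(Br)cc5)c(=O)c5ccccc45)cc3F)ccnc2cc1OCCCN1CCCCC1` gives 410 nM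

Compound 2 differs from compound 1 by nitro in place of bromo on an aromatic carbon. That change produced a 3.9-fold higher number from compound 1 to compound 2 (0.59 log units; beyond the scatter). Compound 3 differs from compound 1 by piperidin-1-yl in place of 4-methylpiperazin-1-yl on a saturated chain carbon, three bonds along the chain from an oxygen on an aromatic ring, a change that produced only a 1.6-fold higher number from compound 1 to compound 3 (0.21 log units; within the scatter), so compound 1 and compound 3 cannot be told apart in this assay. Compound 2 stands apart from compound 3 as well: its number in this assay is higher than the number of compound 3, and that gap is beyond the scatter.

Compound 4 `COc1cc2c(Oc3ccc(NC(=O)c4nn(-c5ccc([N+](=O)[O-])cc5)c(=O)c5ccccc45)cc3F)ccnc2cc1OCCCN1CCCCC1` is not yet measured. It differs from compound 3 by nitro in place of bromo on an aromatic carbon. The place of this change is described in the same words as for the change from compound 1 to compound 2, so it is the same change, now made on the core of compound 3 instead of the core of compound 1. How the two cores differ is given above as the replacement of one amine by another on the propyl chain.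

Among the measured compounds shown here, compound 4 is expected to show a 3.9-fold higher number from compound 3 to compound 4 (0.59 log units; beyond the scatter) in this assay, about the same size as the step from compound 1 to compound 2, because the only measured instance of this change is a 3.9-fold higher number from compound 1 to compound 2 (0.59 log units; beyond the scatter) and the two cores behave alike within the scatter. On that basis compound 4 is estimated at 1600 nM in this assay, with a likely range from 700 nM to 3600 nM. The estimate rests on a single measured pair, so a step of different size would not be surprising.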

Compound 4, half-maximal inhibitory concentration: 1300 nM
Compound 4: middle estimate off by 1.2-fold (0.09 log units), on the high side; low and high end bracket the measured number.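

In this assay, the change from bromo to nitro carries over to the second core with a 3.2-fold higher number from compound 3 to compound 4 (0.50 log units; beyond the scatter), and the step does not differ measurably from the one on the first core: the same change on two cores in this assay, a 3.9-fold higher number (0.59 log units; beyond the scatter) from compound 1 to compound 2 and a 3.2-fold higher number (0.50 log units; beyond the scatter) from compound 3 to compound 4, 1.2-fold (0.09 log units) apart, within the scatter of two such steps
The amine change gives a 1.3-fold higher number from compound 2 to compound 4 (0.12 log units; within the scatter), so compound 2 and compound 4 cannot be told apart in this assay, and this change too reads the same whether the aryl group is 4-bromophenyl or 4-nitrophenyl: the same change on two cores in this assay, a 1.6-fold higher number (0.21 log units; within the scatter) from compound 1 to compound 3 and a 1.3-fold higher number (0.12 log units; within the scatter) from compound 2 to compound 4, 1.2-fold (0.09 log units) apart, within the scatter of two such steps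
Together the four compounds form a closed square in which the two changes add up without visible interaction, but this rests on one pair of cores that differ only in the amine on the propyl chain and on one cell line, so it does not show that the nitro step would hold on a core differing elsewhere, nor does it say why the nitro compounds give the higher numbers.

Open, from the compounds shown here alone, is where other groups on the aryl ring would fall relative to the 4-bromophenyl and 4-nitrophenyl compounds, for example chloro, methoxy or no group at all. Also open, going by these compounds, is whether the same additive reading would survive with a morpholine in place of these two amines, or with a longer chain carrying the amine.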